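Hydroxy in place of fluoro: a solubility estimate

This account rests on a few compounds, and the source may have more. Where it says the series, first, only, none or still open, it means among the compounds named here.

Measured in a physicochemical assay for solubility, at pH 7.4; on this read-out lower numbers stand for lower solubility and higher numbers for higher solubility:
Compound 1 `Cc1c(Cl)cccc1Oc1cccn2c(C34CCC(CC3)C4)nnc12`: 1 ug/mL
Compound 2 `Cc1c(Cl)cccc1Oc1cccn2c(C34CCC(F)(CC3)CC4)nnc12`: 1 ug/mL

Level with compound 1, compound 2 stands at 1 ug/mL, and no other measured value exists in this assay. Compound 3 `Cc1c(Cl)cccc1Oc1cccn2c(C34CCC(O)(CC3)CC4)nnc12` keeps the rest of compound 2 and carries hydroxy in place of fluoro on a saturated ring carbon. Among the measured compounds shown here, one measured step bears on this change, and only indirectly: no change at the digits printed from compound 1 to compound 2 (within the scatter). That step exchanged the whole saturated group and did not test this substitution, so the data hold no direct measure of it. On the structural change alone, an upward move beyond the scatter is expected, estimated as a 5.0-fold higher number from compound 2 to compound 3 (0.70 log units; beyond the scatter). Compound 3 is estimated at 5 ug/mL, with an expected range of 1.5 ug/mL to 25 ug/mL.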

Compound 3, solubility: 11 ug/mL
Compound 3: the middle estimate sits 2.2-fold (0.34 log units) below what was measured; the range from low to high includes it.
By their numbers in this assay, from the lowest: compounds 1 and 2 (each within the scatter of the next); then compound 3.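

In this assay, hydroxy in place of fluoro on a saturated ring carbon gives an 11-fold higher number from compound 2 to compound 3 (1.04 log units; beyond the scatter) and lies beyond the scatter, so this position, three ring bonds from the ring atom that bears a large group, responds to a change of one substituent. The earlier pair could not show this: the exchange of the whole saturated group gave no change at the digits printed from compound 1 to compound 2 (within the scatter) and left the read-out level. Set against the group of compound 1, the hydroxy-bearing group gives an 11-fold higher number from compound 1 to compound 3 (1.04 log units; beyond the scatter) and so separates from both earlier groups, but nothing shown here accounts for the rise.

As far as these compounds go, what remains open is whether the step is particular to hydroxy, or whether methoxy, an amine or a carboxylic acid on the same saturated ring carbon would move the read-out as well. Also open, from the compounds shown here alone, is whether hydroxy would give a step of similar size on the saturated group of compound 1.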